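Swapping a Methyl for Fluorine on a Weak Compound

A few compounds are considered here, and "the series" means these few. Any claim that something is new, unique, unknown or untested is made for them only; others in the source may bear on it.

Compound 1 `C=CCn1c(=O)/c(=C\c2cccc(C)c2)[nH]c(=O)/c1=C\c1ccccc1OC` was tested in a functional assay on K562 cells (Homo sapiens) for cytotoxicity, read by CCK-8 assay, with a stated time of 72 h (on this read-out lower numbers stand for stronger inhibition and higher numbers for weaker inhibition), where compound 1 gives 8800 nM. Going by the values given here, that is the higher of the two numbers measured so far: compound 2 `COc1ccccc1/C=c1\c(=O)[nH]/c(=C/c2cccc(Cl)c2Cl)c(=O)n1C` gives 110 nM, a much lower number, beyond the usual scatter. Compound 3 `C=CCn1c(=O)/c(=C\c2ccc(Cl)c(Cl)c2)[nH]c(=O)/c1=C\c1ccccc1` was reported as "not active" (no number reported), with no number given. Compound 4 `C=CCn1c(=O)/c(=C\c2cccc(F)c2)[nH]c(=O)/c1=C\c1ccccc1OC` differs from compound 1 by a single change, (fluoro in place of methyl on an aromatic carbon), and otherwise shares its core. Among the compounds with values here, no pair of measured compounds carries this same change, so there is no direct guide to its effect. The expectation is a step that stays within the usual scatter, in no clear direction: a 1.1-fold lower number from compound 1 to compound 4 (0.04 log units; within the scatter). Compound 4 is therefore estimated at 8000 nM, with a range from 3000 nM to 25000 nM.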

Compound 4, half-maximal inhibitory concentration: 4100 nM
For compound 4 the middle estimate is 2.0-fold (0.29 log units) above the measured one, within the range that was stated.
By their numbers in this assay, from the lowest: compound 2; then compound 4; then compound 1.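

Replacing methyl with fluoro on this ring, the change from 3-methylphenyl to 3-fluorophenyl, gives a 2.1-fold lower number from compound 1 to compound 4 (0.33 log units; beyond the scatter) in this assay. Going by these compounds alone, this is the first step here that isolates one place, as the earlier compounds differ from each other in more than one, and it shows that this position responds to a single-atom swap, though modestly. Nothing available explains the shift. From the compounds shown here alone, how an amine or a nitrile would behave at this same place remains open. So does whether this swap gives a similar step on the core of compound 2.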